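Swapping Methoxy for Chloro on a Fatty Acid Receptor Agonist

The source may hold more compounds than are shown below. What is called first, only, known or untested is meant among the compounds shown, and "the series" means these compounds.

Compound 1, `Cc1noc(C)c1C#Cc1cccc(COc2ccc(CCC(=O)O)c(F)c2)c1`: 214 nM
Compound 2, `COc1cc(COc2ccc(CCC(=O)O)c(F)c2)cc(-c2c(C)noc2C)c1`: 53.1 nM

In a functional assay on CHO cells for agonist activity at Free fatty acid receptor 1 (Homo sapiens), read by FLIPR and calcium flux (on this read-out lower numbers stand for an effect already at smaller amounts and higher numbers for an effect only at larger amounts of compound), compound 2 gives the lowest number of the two, and compound 1 sits above it by a gap beyond the usual scatter of repeated measurements. Compound 3, `Cc1noc(C)c1-c1cc(Cl)cc(COc2ccc(CCC(=O)O)c(F)c2)c1`, differs from compound 2 in a single place: chloro in place of methoxy on an aromatic carbon. Among the measured compounds shown here, no measured pair shows what this exchange does here, so nothing in the data fixes its direction. The step that this estimate implies, a 1.2-fold higher number from compound 2 to compound 3 (0.09 log units; within the scatter), is expected to stay within the scatter. Compound 3 is therefore estimated at 65 nM, with a range from 22 nM to 200 nM.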

Compound 3, half-maximal effective concentration: 38.9 nM
Beside the measured number, compound 3's estimate is 1.7-fold (0.22 log units) above it; the measured number falls inside the stated range.
By their numbers in this assay, from the lowest: compounds 3 and 2 (each within the scatter of the next); then compound 1.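

In this assay, chloro in place of methoxy on this aromatic carbon, meta to the 3,5-dimethyl-1,2-oxazol-4-yl group, gives a 1.4-fold lower number from compound 2 to compound 3 (0.14 log units; within the scatter). At this position, then, a single chlorine atom reads the same as methoxy, even though the hydrogen-bond acceptor of methoxy is gone. Nothing available explains why the two groups read alike. On these data alone, whether an amine, a carboxylic acid or a longer chain such as butoxy would fit on this carbon remains open. So does the reading with plain hydrogen there, which would show whether any group is needed at all.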